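This account rests on a few compounds, and the source may have more. Where it says the series, first, only, none or still open, it means among the compounds named here.

Measured so far in an assay on membranes from HeLa cells for displacement of a labelled ligand from adenosine receptor A3 (Homo sapiens), read by scintillation counting, with a stated time of 180 min, tested at 1 uM; a higher number here means more inhibition at the concentration tested (going by the name of the read-out), a lower number less inhibition:

Compound 1, `CC1=C(C(=O)OC2CCCC2)C(c2cccs2)NC(=O)N1`, gives 1%.
Compound 2, `CC1=C(C(=O)OC2CCCCC2)C(c2cccs2)NC(=O)N1`, gives 1%.
Compound 3, `CC1=C(C(=O)OC2CCCC2)C(c2ccsc2)NC(=O)N1`, gives 5%.

Compound 4, `CC1=C(C(=O)OC2CCCCC2)C(c2ccsc2)NC(=O)N1`, has not yet been measured in this assay.

The change from compound 3 to compound 4 is cyclohexyl in place of cyclopentyl on an oxygen next to a carbonyl group. The same change is found once among the measured compounds, between compound 1 and compound 2: cyclohexyl in place of cyclopentyl on an oxygen next to a carbonyl group. The place of the change is described in the same words in both pairs, so it counts as the same change. In this assay that earlier instance gave no change at the digits printed from compound 1 to compound 2 (within the scatter).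

The core of compound 3 differs from the core of compound 1 in one way: thiophen-3-yl in place of thiophen-2-yl on a saturated ring carbon. In this assay this difference gave a number 4 percentage points higher from compound 1 to compound 3 (within the scatter), so all three measured numbers sit close together and none of the three stands apart from the others.

For the measured compounds named here, for compound 4 the expected step in this assay is a number 1 percentage points lower from compound 3 to compound 4 (within the scatter), since the only earlier instance of the change showed no change at the digits printed from compound 1 to compound 2 (within the scatter) and compound 3 itself gives 5%. Two pairs are a thin basis, and the different core of compound 3 is not known to behave the same way. The expected value for compound 4 in this assay is 4%, estimated to fall between 0% and 12%.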

Compound 4, a percentage reported as inhibition, at one concentration (the size of the read-out at that concentration, not a potency): 1%
Beside the measured number, compound 4's estimate is 3 percentage points above it, within the range that was stated.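

In this assay, cyclohexyl in place of cyclopentyl on the core of compound 3 gives a number 4 percentage points lower from compound 3 to compound 4 (within the scatter), and this step does not differ from the earlier instance on the core of compound 1: the same change on two cores in this assay, no change at the digits printed (within the scatter) from compound 1 to compound 2 and a number 4 percentage points lower (within the scatter) from compound 3 to compound 4, 4 percentage points apart, within the scatter of two such steps. Thiophen-3-yl in place of thiophen-2-yl, on the cyclohexyl side of the set, gives no change at the digits printed from compound 2 to compound 4 (within the scatter), and this too does not differ from its earlier instance on the cyclopentyl side: the same change on two cores in this assay, a number 4 percentage points higher (within the scatter) from compound 1 to compound 3 and no change at the digits printed (within the scatter) from compound 2 to compound 4, 4 percentage points apart, within the scatter of two such steps. So in these four compounds both changes carry from one core to the other without a difference that can be told from scatter, but every step lies within the scatter and all four numbers sit together at the low end of the scale, which shows only that neither change lifts the read-out on these cores and does not show that the steps would stay the same on a compound with clear inhibition.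

The compounds shown leave open what a longer chain or a benzyl group would do on the oxygen next to the carbonyl group. They also leave open what a phenyl group, or a thiophene carrying an amine or a carboxylic acid, would do on the saturated ring carbon.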